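Aryl variation on the shared core: cytotoxicity notes

The compounds below may be only part of what the source reports. "The series", "measured", "known", "first", "only" and "open" are said of these compounds alone.

Compound 1 `O=c1oc2ccccc2c2nc3c(ccc4cc[nH]c43)c(-c3c(Cl)cccc3Cl)c12` carries a 2,6-dichlorophenyl on an aromatic carbon of the shared core; in a functional assay on B16-F10 cells (Mus musculus) for cytotoxicity (on this read-out higher numbers stand for weaker inhibition and lower numbers for stronger inhibition), compound 1 gives 70700 nM. Compound 2 `O=c1oc2ccccc2c2nc3c(ccc4cc[nH]c43)c(-c3ccccn3)c12` bears pyridin-2-yl in place of 2,6-dichlorophenyl on an aromatic carbon, and in this assay compound 2 gives 70700 nM. The step of no change at the digits printed from compound 1 to compound 2 (within the scatter) shows the aryl swap at this position leaving the read-out unmoved. Compound 2 therefore stands level with compound 1 at the digits shown, and it has no other measured neighbour.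

Compound 3 `O=c1oc2ccccc2c2nc3c(ccc4cc[nH]c43)c(-c3ccccc3)c12` differs from compound 2 by phenyl in place of pyridin-2-yl on an aromatic carbon. Within the data shown here, the only step bearing on this change is the one already described, which was within the scatter, so in this assay no step beyond the scatter is expected in either direction; the expected step is no change at the digits printed from compound 2 to compound 3 (within the scatter). For compound 3 the estimate in this assay is 70700 nM, expected between 35000 nM and 141000 nM.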

Compound 3, half-maximal inhibitory concentration: 70700 nM
Compound 3: middle estimate and measured number agree at the digits printed; measured number inside the range.
By their numbers in this assay, from the lowest: compounds 1, 2 and 3 (each within the scatter of the next).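

In this assay, phenyl in place of pyridin-2-yl gives no change at the digits printed from compound 2 to compound 3 (within the scatter), so exchanging the ring nitrogen of the pyridin-2-yl for carbon leaves the read-out where it was. Phenyl in place of 2,6-dichlorophenyl gives no change at the digits printed from compound 1 to compound 3 (within the scatter), which extends the same flat picture to removal of both chlorines from the aryl ring, a comparison the first pair could not make. No supporting data are available to explain why these three aryl groups read alike.

From the compounds shown here alone, all three groups are six-membered aromatic rings, so the effect of an amine, a carboxylic acid or a longer alkyl chain at this position remains open. Among these compounds, also open is whether any change here can move the number on these cells, since no step so far lies beyond the scatter.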